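Cytotoxicity notes on the naphthyl carbinol series

The compounds below may be only part of what the source reports. "The series", "measured", "known", "first", "only" and "open" are said of these compounds alone.

Measured so far:
compound 1, `COc1nc(-c2ccccc2F)ccc1[C@@H](c1ccccc1)[C@@](O)(CCN(C)C)c1cccc2ccccc12`, a toxicity assay on HeLa cells (Homo sapiens) for cytotoxicity; a higher number here means that more compound is tolerated, a lower number that less compound is tolerated: "nd" (no result reported)
compound 2, `COc1nc(-c2ccc(Br)cc2)ccc1[C@@H](c1ccccc1)[C@@](O)(CCN(C)C)c1cccc2ccccc12`, this assay: > 64 ug/mL, a limit of the assay rather than a number
compound 3, `COc1nc(-c2cccc(F)c2)ccc1[C@@H](c1ccccc1)[C@@](O)(CCN(C)C)c1cccc2ccccc12`, this assay: 62.8 ug/mL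

Compound 1 has no number in this assay; of the values shown, one sits at a limit (the limit of > 64 ug/mL in this assay, at which 1 of the 3 values shown sits). Within the data shown here, the only measured step, an at least 1.0-fold lower number from compound 2 to compound 3 (0.00 log units; that floor lies within the scatter), lies within the scatter, and nothing measured bears directly on the change from compound 1 to compound 4, `COc1nc(C2CCOCC2)ccc1[C@@H](c1ccccc1)[C@@](O)(CCN(C)C)c1cccc2ccccc12`, which is oxan-4-yl in place of 2-fluorophenyl on an aromatic carbon. Among the measured compounds shown here, with no step pointing either way, compound 4 is expected to sit where compounds 2 and 3 do, near the top of the range, estimated at 60 ug/mL, between 30 ug/mL and 64 ug/mL.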

Compound 4, half-maximal cytotoxic concentration: 22.5 ug/mL
Compound 4: middle estimate off by 2.7-fold (0.43 log units), on the high side; the measured number lies below the stated range.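

In this assay, among these compounds, oxan-4-yl is the first group on this aromatic carbon, next to the ring nitrogen, to give a change beyond the scatter, with a 2.8-fold lower number from compound 3 to compound 4 (0.45 log units; beyond the scatter). Against the 4-bromophenyl group the reading is an at least 2.8-fold lower number from compound 2 to compound 4 (0.45 log units; beyond the scatter). That step is a floor, as compound 2 gives a limit and not a number: the limit of > 64 ug/mL in this assay, at which 1 of the 4 values shown sits.

Steps from compound 1 cannot be read, leaving the change from 2-fluorophenyl without a direct reading. Going by these compounds, whether the lower number goes with the ring oxygen or with the loss of the aromatic ring stays open, and a cyclohexyl group or a piperidin-4-yl amine on this carbon would bear on that.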